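Bromo to methylsulfonyl on a scaffold showing no cytotoxicity

This account rests on a few compounds, and the source may have more. Where it says the series, first, only, none or still open, it means among the compounds named here.

Compound 1 `CCOC(=O)c1cnc(N2CCN(Cc3ccc(C#N)cc3)CC2)nc1Oc1c(C)cc(-c2ccc(C#N)cc2)cc1C`: in an ADME assay on MT4 cells (Homo sapiens) for cytotoxicity, read by MTT assay, with a stated time of 4 days (on this read-out higher numbers stand for lower toxicity in this test and lower numbers for higher toxicity in this test), compound 1 gives only a limit, > 125000 nM.
Compound 2 `CCOC(=O)c1cnc(N2CCN(Cc3ccc(Br)cc3)CC2)nc1Oc1c(C)cc(-c2ccc(C#N)cc2)cc1C`: in this assay compound 2 also gives only a limit, > 125000 nM.

Compound 2 therefore stands at the upper edge of what this test can report, with no exact number attached to it. Among the compounds with values here, the only comparison available, a step that the two limits leave unreadable from compound 1 to compound 2, cannot be read, and the one general observation is the limit of > 125000 nM in this assay, at which 2 of the 2 values shown sit. Nothing in these two results separates the two compounds from each other.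

Compound 3 `CCOC(=O)c1cnc(N2CCN(Cc3ccc(S(C)(=O)=O)cc3)CC2)nc1Oc1c(C)cc(-c2ccc(C#N)cc2)cc1C` differs from compound 2 by methylsulfonyl in place of bromo on an aromatic carbon. No measured step bears on this change, since the single step shown is unreadable, so no direction can be taken from the data. The expectation is that compound 3 behaves like the two compounds already measured, with the step that the limit leaves unreadable from compound 2 to compound 3 expected to be nothing beyond the scatter. Compound 3 is estimated at 150000 nM, within a range from 60000 nM to 400000 nM, and most likely reported again only as a limit.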

Compound 3, half-maximal cytotoxic concentration: > 125000 nM
Compound 3 ended at the assay's limit; the forecaster's own chance of this, stated with the estimate: 85%; the middle value does not contradict the limit.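

No step among compound 1, compound 2 and compound 3 can be read in this assay, since each gives only a limit and not a number: the limit of > 125000 nM in this assay, at which 3 of the 3 values shown sit.

The compounds shown leave open whether cyano, bromo or methylsulfonyl makes any difference to cytotoxicity, and at what concentration, if any, these compounds would harm the cells.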